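A few compounds are considered here, and "the series" means these few. Any claim that something is new, unique, unknown or untested is made for them only; others in the source may bear on it.

The measured compounds so far:
compound 1, `O=C(C1CCC1)N1CCc2nc(C#Cc3ccccc3)sc2C1`, which in an assay on HEK293 cells for negative allosteric modulation of metabotropic glutamate receptor 5 (Homo sapiens), read by FLIPR, with a stated time of 1 h (a higher number here means a weaker inhibitor, a lower number a stronger inhibitor), gives 370 nM
compound 2, `O=S(=O)(C1CC1)N1CCc2nc(C#Cc3ccccc3)sc2C1`, which in this assay gives 34 nM

Going by the values given here, of the two numbers, compound 2 holds the lower one; its nearest neighbour is compound 1, and the single measured step, an 11-fold lower number from compound 1 to compound 2 (1.04 log units; beyond the scatter), lies beyond the scatter. That step, however, changed the group on the ring nitrogen as a whole, replacing a cyclobutylcarbonyl by a cyclopropylsulfonyl, so it speaks only indirectly to the change now at hand.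

The next compound, compound 3, `O=S(=O)(N1CCCCC1)N1CCc2nc(C#Cc3ccccc3)sc2C1`, keeps the sulfonyl on the ring nitrogen and alters only what sits on the sulfur: piperidin-1-yl in place of cyclopropyl on a sulfonyl sulfur. Among the compounds with values here, no measured pair isolates this exchange; the step from compound 1 to compound 2 shows only that a sulfonyl-bearing ring nitrogen is tolerated well here. Within the data shown here, with no direct precedent, a modest step in this assay is expected, if any, with weakening somewhat more likely than gain. The estimated step is a 2.1-fold higher number from compound 2 to compound 3 (0.31 log units; beyond the scatter). Compound 3 is therefore expected to give 70 nM, within a range of 20 nM to 250 nM.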

Compound 3, half-maximal inhibitory concentration: 780 nM
Compound 3: the middle estimate sits 11-fold (1.05 log units) below what was measured, and the stated range ends below it.
By their numbers in this assay, from the lowest: compound 2; then compound 1; then compound 3.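

With the sulfonyl on the ring nitrogen kept in place, piperidin-1-yl takes the place of cyclopropyl on the sulfonyl sulfur. In this assay this exchange goes with a 23-fold higher number from compound 2 to compound 3 (1.36 log units; beyond the scatter), and the sulfonyl alone does not secure a low number. The earlier step replaced the whole group on the ring nitrogen and could not show this; the new one shows that the result also depends strongly on what the sulfur carries, and its direction is opposite to that of an 11-fold lower number from compound 1 to compound 2 (1.04 log units; beyond the scatter) in this series. Nothing available here accounts for the size of this change, and no cause can be assigned to it.

The exchange replaces a three-membered ring of carbon only with a six-membered ring containing one nitrogen, so this single pair cannot separate ring size from the presence of that nitrogen. A cyclohexyl group on the sulfur would bear on the first question and a dimethylamino group on the second, while a methyl group would show how a smaller group without a ring fares at this position.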